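A Bromo for Ethynyl Swap in a Cytotoxic Series

A few compounds are considered here, and "the series" means these few. Any claim that something is new, unique, unknown or untested is made for them only; others in the source may bear on it.

In a functional assay on SK-BR-3 cells (Homo sapiens) for cytotoxicity, read by resazurin assay (a higher number here means a weaker inhibitor, a lower number a stronger inhibitor), compound 1 (`C#Cc1cccc(Nc2ncnc3cc(NC(=O)c4ccc(C(=O)Nc5ccccc5N)cc4)ccc23)c1`) gives 39000 nM as its half-maximal inhibitory concentration. Compound 2 (`C#Cc1cccc(Nc2ncnc3ccc(NC(=O)c4ccc(C(=O)Nc5ccccc5N)s4)cc23)c1`) stands at > 50000 nM and that is a limit of the assay, not a number. Compound 3 (`C#Cc1cccc(Nc2ncnc3ccc(OCc4ccc(C(=O)Nc5ccccc5N)cc4)cc23)c1`) gives 3400 nM and holds the lowest of the two actual numbers, with compound 1 higher by a gap beyond the scatter.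

Compound 4 (`Nc1ccccc1NC(=O)c1ccc(COc2ccc3ncnc(Nc4cccc(Br)c4)c3c2)cc1`) has yet to be measured. Its difference from compound 3 is bromo in place of ethynyl on an aromatic carbon and amounts to bromo in place of ethynyl on an aromatic carbon, meta to a large group. Within the data shown here, no measured pair isolates this change, so the expectation rests on the swap itself. Taking compound 3 at 3400 nM as the reference, no shift beyond the scatter is expected in this assay in either direction. The expected move is a 1.1-fold lower number from compound 3 to compound 4 (0.05 log units; within the scatter) and counts as small. The estimate for compound 4 is 3000 nM with an expected range from 1000 nM to 10000 nM for the coming measurement.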

Compound 4, half-maximal inhibitory concentration: 5100 nM
Beside the measured number, compound 4's estimate is 1.7-fold (0.23 log units) below it, and the stated range covers the measured number.
By their numbers in this assay, from the lowest: compounds 3 and 4 (each within the scatter of the next); then compound 1. At a limit, above all of these: compound 2.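

Setting bromo in place of ethynyl on this aromatic carbon, meta to a large group, gives a 1.5-fold higher number from compound 3 to compound 4 (0.18 log units; within the scatter) in this assay and so leaves the two compounds indistinguishable there. Among these compounds, compounds 1, 2 and 3 all carry ethynyl, so only this pair shows that the position tolerates the exchange of a two-carbon group with its triple bond for a single bromine atom, at least on the framework of compound 3. Nothing measured here accounts for this outcome.

On these data alone, what an amine, a carboxylic acid or a methoxy group would do at this position remains open. As far as these compounds go, it is also open whether the same exchange would behave alike in compound 1 or compound 2, whose linkers differ from that of compound 3.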